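Swapping 3-methylphenyl for 4-chlorophenyl in an antiproliferative series

This account rests on a few compounds, and the source may have more. Where it says the series, first, only, none or still open, it means among the compounds named here.

Values measured in a functional assay on A549 cells (Homo sapiens) for antiproliferative activity, read by MTT assay; a lower number here means a stronger inhibitor, a higher number a weaker inhibitor:
compound 1 `Cc1cccc(Nc2nccc(-c3ccc(Br)cc3)n2)c1` gives 63200 nM
compound 2 `COc1cccc(Nc2nccc(-c3ccc(F)cc3)n2)c1` gives 35900 nM
compound 3 `COc1cccc(Nc2nccc(-c3ccc(Cl)c(Cl)c3)n2)c1` gives 6000 nM

Compound 1 stands at the upper end of these numbers. Its value and that of compound 2 lie within the usual scatter of each other, so the two cannot be told apart. Compound 3 lies lower than compound 1, and that gap is well beyond the scatter.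

The next compound to be tested is compound 4 `Clc1ccc(Nc2nccc(-c3ccc(Br)cc3)n2)cc1` and it has not yet been measured. It carries 4-chlorophenyl in place of 3-methylphenyl on a nitrogen on an aromatic ring and keeps the rest of compound 1 unchanged. Among the measured compounds shown here, no pair of measured compounds differs in one place only, so the data give no direct measure of such a change. Compound 1 at 63200 nM has room to fall, and compound 3 at 6000 nM shows that lower numbers occur in this small set. A modest move toward a lower number in this assay is therefore expected, not far beyond the scatter. The expected change is a 2.5-fold lower number from compound 1 to compound 4 (0.40 log units; beyond the scatter) in this estimate. For compound 4 the estimated value is 25000 nM with an expected range from 7000 nM to 80000 nM in repeat measurements.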

Compound 4, half-maximal inhibitory concentration: 6110 nM
Estimate against measurement, compound 4: 4.1-fold (0.61 log units) above; measured number outside the range, below it.
By their numbers in this assay, from the lowest: compounds 3 and 4 (each within the scatter of the next); then compounds 2 and 1 (each within the scatter of the next).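

In this assay, among the compounds shown here, putting 4-chlorophenyl in place of 3-methylphenyl on a nitrogen on an aromatic ring gives a 10-fold lower number from compound 1 to compound 4 (1.01 log units; beyond the scatter), the only change in this set made in one place, and it shows that activity responds strongly to the group held at this position. The two groups match in everything counted here: each has the same number of heavy atoms, each is one six-membered aromatic ring of carbon only, and neither has hydrogen-bond donors, hydrogen-bond acceptors or a net charge, so a large step can arise at this position with all of these counts unchanged. No measurement at hand accounts for the size of this step.

Since 3-methylphenyl and 4-chlorophenyl differ both in the group on the ring and in where it sits, the compounds shown leave open whether the chlorine or its location goes with the lower number. They also leave open how this position would respond to 4-methylphenyl, 3-chlorophenyl or a phenyl ring carrying a carboxylic acid, and whether the step would hold with a change elsewhere in compound 1.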